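From compound 3 to compound 4: an ethoxy swap

The source may report more compounds than this note shows. Statements on the series, on what has been measured and on what is new or still open speak of the compounds shown alone.

Of the compounds shown here, three have so far been measured in a physicochemical assay for solubility, at pH 6.8; on this read-out lower numbers stand for lower solubility and higher numbers for higher solubility. Compound 1 `COC(=O)c1nc(-c2ccco2)c(C(F)(F)F)cc1N` gives 11 ug/mL, compound 2 `Nc1cc(C(F)(F)F)c(Br)nc1C(=O)NCC(O)(C(F)(F)F)C(F)(F)F` gives 3 ug/mL, and compound 3 `C[C@](O)(CNC(=O)c1nc(C(F)(F)F)c(C(F)(F)F)cc1N)C(F)(F)F` gives 82 ug/mL, the highest of the three and beyond the scatter from both others. Compound 4 `CCOc1nc(C(=O)NC[C@](C)(O)C(F)(F)F)c(N)cc1C(F)(F)F` is still unmeasured. It carries ethoxy in place of trifluoromethyl on an aromatic carbon, next to the ring nitrogen: ethoxy in place of trifluoromethyl on an aromatic carbon. Going by the values given here, no two measured compounds differ in just one place, so the data offer no direct guide to this change. Compound 3 already stands at the top with 82 ug/mL, so a moderate drop in this assay is expected. The expected size is a step of a 2.3-fold lower number from compound 3 to compound 4 (0.37 log units; beyond the scatter). For compound 4 the estimate is 35 ug/mL, within an expected range of 10 ug/mL to 110 ug/mL.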

Compound 4, solubility: 60 ug/mL
Beside the measured number, compound 4's estimate is 1.7-fold (0.23 log units) below it; low and high end bracket the measured number.
By their numbers in this assay, from the lowest: compound 2; then compound 1; then compounds 4 and 3 (each within the scatter of the next).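

In this assay, going by these compounds alone, ethoxy in place of trifluoromethyl on this aromatic carbon, next to the ring nitrogen, gives a 1.4-fold lower number from compound 3 to compound 4 (0.14 log units; within the scatter), the first step in the set that changes only one place. The two compounds therefore cannot be told apart on this read-out, so trifluoromethyl at this position is not required to keep solubility at the level of compound 3. No measurement shown here explains this result.

As far as these compounds go, whether an amine or a longer chain such as propoxy would fare the same at this position remains open. So does whether this swap gives a similar result with a different amide side chain.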